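Triazole Replaces Sulfonyl Pyrrolidine: Cytotoxicity Expectation

This account rests on a few compounds, and the source may have more. Where it says the series, first, only, none or still open, it means among the compounds named here.

Compound 2 `O=C(Nc1cccc(S(=O)(=O)N2CCCC2)c1)C1CCCN(C(=O)c2cc(C(F)(F)F)cc(C(F)(F)F)c2)C1` shows no measurable inhibition in an ADME assay on PC-3 cells (Homo sapiens) for cytotoxicity, read by WST assay, tested at 100 uM (a higher number here means more inhibition at the concentration tested (going by the name of the read-out), a lower number less inhibition), giving 0%. Among the measured compounds shown here, compound 1 `O=C(Nc1cccc(N2CCCC2=O)c1)C1CCCN(C(=O)c2cc(C(F)(F)F)cc(C(F)(F)F)c2)C1` likewise gives 0% in this assay, and the only measured step, no change at the digits printed from compound 1 to compound 2 (within the scatter), stays within the scatter. Compound 3 `Cn1cnnc1-c1cccc(NC(=O)C2CCCN(C(=O)c3cc(C(F)(F)F)cc(C(F)(F)F)c3)C2)c1` differs from compound 2 by 4-methyl-4H-1,2,4-triazol-3-yl in place of (pyrrolidin-1-yl)sulfonyl on an aromatic carbon. For the measured compounds named here, with the numbers of both measured compounds level and the one step flat, nothing suggests a shift beyond the scatter in this assay. Compound 3 is therefore expected to give 0%, in a range from -5% to 10%. The step of no change at the digits printed from compound 2 to compound 3 (within the scatter) is expected to be none beyond the scatter.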

Compound 3, a percentage reported as inhibition, at one concentration (the size of the read-out at that concentration, not a potency): 0%
Compound 3: the middle estimate sits on the measured number at the digits printed; measured number inside the range.
By their numbers in this assay, from the lowest: compounds 1, 2 and 3 (each within the scatter of the next).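

In this assay, an aromatic ring at this place, the 4-methyl-4H-1,2,4-triazol-3-yl, gives the same reading as the non-aromatic rings before it (no change at the digits printed from compound 2 to compound 3 (within the scatter); no change at the digits printed from compound 1 to compound 3 (within the scatter)). The flat reading therefore now extends to a group with neither the sulfonyl of compound 2 nor the carbonyl of compound 1. Nothing available explains why the reading stays flat. On these data alone, whether an amine or a carboxylic acid on this aromatic carbon would read differently stays open. So does the effect of replacing the trifluoromethyl groups elsewhere on the shared core.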